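This account rests on a few compounds, and the source may have more. Where it says the series, first, only, none or still open, it means among the compounds named here.

Notes on the series. Compound 1 `COc1ccc(NC(=O)Nc2cc(C)nc3ccccc23)cc1` is the starting point for the present step. In an ADME assay on HEK293 cells (Homo sapiens) for cytotoxicity, with a stated time of 72 h (a higher number here means that more compound is needed for the effect, a lower number that less compound is needed), compound 1 gives > 25000 nM, which is a limit of the assay and not a number, so compound 1 has no measured position on the scale. The two other measured compounds return the same kind of result. Compound 2 `COc1ccc(NC(=O)Nc2cc(C)nc3ccccc23)cc1F` gives > 25000 nM in this assay, again a limit. Compound 3 `Cc1cc(NC(=O)Nc2ccccc2OC(F)(F)F)c2ccccc2n1` gives > 25000 nM in this assay, again a limit. Among the compounds with values here, the only measured single-point step, a step that the two limits leave unreadable from compound 1 to compound 2, therefore cannot be sized, and the whole of the evidence reduces to the limit of > 25000 nM in this assay, at which 3 of the 3 values shown sit.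

Compound 4 `Cc1cc(NC(=O)Nc2ccc(C(N)=O)cc2)c2ccccc2n1` differs from compound 1 by carbamoyl in place of methoxy on an aromatic carbon. Within the data shown here, no measured step concerns a carbamoyl or a methoxy, and the one step that exists is of another kind and unreadable, so nothing here indicates a step in either direction beyond the scatter in this assay. The working expectation is therefore a step that the limit leaves unreadable from compound 1 to compound 4, with compound 4 expected to sit at the same limit as its neighbours. The estimate for compound 4 in this assay is 40000 nM, with an expected range from 15000 nM to 150000 nM.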

Compound 4, half-maximal effective concentration: > 25000 nM
Compound 4 gave a limit, no number; the forecaster's own chance of this, stated with the estimate: 85%; the middle value does not contradict the limit.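

Within the data shown here, compound 1 and compound 4 both return limits in this assay, so carbamoyl in place of methoxy gives no step that can be read. The evidence stays as it was: the limit of > 25000 nM in this assay, at which 4 of the 4 values shown sit. The compounds shown leave open where any of them would sit on the scale, and which change, if any, would give a measurable value.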